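Uracil nucleotide series: two-position substituent and phosphate chain

A few compounds are considered here, and "the series" means these few. Any claim that something is new, unique, unknown or untested is made for them only; others in the source may bear on it.

Within the data shown here, compound 2 `O=c1ccn([C@@H]2O[C@H](COP(=O)(O)OP(=O)(O)O)[C@@H](O)[C@H]2O)c(SCc2ccccc2)n1` gives 6800 nM in an in vitro functional assay on 1321-N1 cells for agonist activity at P2Y purinoceptor 6 (Homo sapiens), read by scintillation proximity assay and inositol phosphate accumulation (a higher number here means that more compound is needed for the effect, a lower number that less compound is needed), and is the only compound here with a number rather than a limit. Compound 3 `O=c1ccn([C@@H]2O[C@H](COP(=O)(O)O)[C@@H](O)[C@H]2O)c(SCc2ccccc2)n1` differs from compound 2 by a group of 4 heavy atoms (3 oxygen, 1 phosphorus; no ring) in place of a hydrogen atom, on an oxygen; the step of an at least 14-fold higher number from compound 2 to compound 3 (1.16 log units; beyond the scatter). In this assay compound 3 sits at the limit > 100000 nM. Compound 1 `CNc1nc(=O)ccn1[C@@H]1O[C@H](COP(=O)(O)O)[C@@H](O)[C@H]1O` also sits at the limit > 100000 nM in this assay. The change from compound 3 to compound 1 is methylamino in place of benzylsulfanyl on an aromatic carbon, and the step that the two limits leave unreadable from compound 3 to compound 1 because both values rest on (the limit of > 100000 nM in this assay, at which 2 of the 3 values shown sit).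

Compound 4 `CNc1nc(=O)ccn1[C@@H]1O[C@H](COP(=O)(O)OP(=O)(O)O)[C@@H](O)[C@H]1O` is not yet measured. From compound 2 it differs by methylamino in place of benzylsulfanyl on an aromatic carbon, the same kind of change as from compound 3 to compound 1, with the place described in identical words for both pairs. The measured pair gives no readable size for this change, so the step from compound 2 to compound 4 is expected near a 1.5-fold higher number from compound 2 to compound 4 (0.17 log units; within the scatter), resting only on compound 2 showing 6800 nM. Compound 4 is therefore estimated at 10000 nM in this assay, somewhere within 1500 nM to 80000 nM, with a real chance of a limit again.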

Compound 4, half-maximal effective concentration: > 100000 nM
Compound 4 was reported as a limit (the forecaster's own chance of this, stated with the estimate: 30%); middle value at least 10-fold (1.00 log units) from the limit.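

On the core of compound 2, methylamino in place of benzylsulfanyl on an aromatic carbon gives an at least 14-fold higher number from compound 2 to compound 4 (1.16 log units; beyond the scatter) in this assay, so this change is not tolerated on the diphosphate-bearing compounds shown. The value of compound 4, > 100000 nM, is a limit of the assay and not a number. Whether the change has the same size on the core of compound 3 is not shown, and neither the step from compound 3 to compound 1 nor the step from compound 1 to compound 4 can be read, because both pairs rest on a shared limit: the limit of > 100000 nM in this assay, at which 3 of the 4 values shown sit.

Only benzylsulfanyl and methylamino are shown on this carbon, so it remains open whether a phenethylsulfanyl, a methylsulfanyl or a benzylamino group would keep or lose the response seen with compound 2. The phosphate chain is also open beyond the two lengths shown, for example a triphosphate carrying benzylsulfanyl.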